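Replacing the dimethylaminophenyl group with ethylphenyl in urea series

This account rests on a few compounds, and the source may have more. Where it says the series, first, only, none or still open, it means among the compounds named here.

The three measured compounds share one core and differ only in the aryl ring attached to an amide-type nitrogen of the urea. Compound 1 `O=C(Nc1cccc(CNc2nccnc2Cl)c1)Nc1ccccc1F` carries a 2-fluorophenyl there, compound 2 `O=C(Nc1cccc(CNc2nccnc2Cl)c1)Nc1ccc(Cl)cc1Br` a 2-bromo-4-chlorophenyl, and compound 3 `CN(C)c1ccc(NC(=O)Nc2cccc(CNc3nccnc3Cl)c2)cc1` a 4-(dimethylamino)phenyl. In a functional assay on T-24 cells (Homo sapiens) for antiproliferative activity, read by MTT assay, with a stated time of 48 h (a lower number here means a stronger inhibitor, a higher number a weaker inhibitor), compound 1 gives 7450 nM, compound 2 gives 6650 nM, and compound 3 gives 20200 nM. Compound 3 thus has the highest number of the three, and both of its steps from the other compounds are beyond the scatter: a 2.7-fold higher number from compound 1 to compound 3 (0.43 log units; beyond the scatter) and a 3.0-fold higher number from compound 2 to compound 3 (0.48 log units; beyond the scatter). Between compound 1 and compound 2 the step is within the scatter: a 1.1-fold lower number from compound 1 to compound 2 (0.05 log units; within the scatter).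

Compound 4 `CCc1ccccc1NC(=O)Nc1cccc(CNc2nccnc2Cl)c1` is the next member, not yet measured in this assay. Its change from compound 3 is 2-ethylphenyl in place of 4-(dimethylamino)phenyl on an amide-type nitrogen. This change runs in the opposite direction to the two steps that reached compound 3: it removes the 4-(dimethylamino)phenyl and installs another phenyl bearing a single substituent at the 2-position, as compound 1 and compound 2 do. Those two steps were modest but beyond the scatter, so a modest drop in the number is expected, of about the same size: a 2.7-fold lower number from compound 3 to compound 4 (0.43 log units; beyond the scatter). Compound 4 is therefore estimated at 7500 nM, with a range from 3500 nM to 16000 nM.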

Compound 4, half-maximal inhibitory concentration: 8720 nM
The estimate for compound 4 lay 1.2-fold (0.07 log units) below the measured number; the measured number falls inside the stated range.
By their numbers in this assay, from the lowest: compounds 2, 1 and 4 (each within the scatter of the next); then compound 3.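

Swapping the 4-(dimethylamino)phenyl for 2-ethylphenyl, a group of carbon only, lowers the number in this assay (a 2.3-fold lower number from compound 3 to compound 4 (0.36 log units; beyond the scatter)), so the higher number of compound 3 goes with that one aryl group and not with the shared core. Compound 4 also sits level with the two halogen-bearing compounds (a 1.2-fold higher number from compound 1 to compound 4 (0.07 log units; within the scatter); a 1.3-fold higher number from compound 2 to compound 4 (0.12 log units; within the scatter)), which shows that the ring on this amide-type nitrogen can carry an ethyl instead of fluoro, or instead of bromo and chloro, without the number moving beyond the scatter. Among these four compounds, 2-fluorophenyl, 2-bromo-4-chlorophenyl and 2-ethylphenyl form one level and only the 4-(dimethylamino)phenyl stands apart, although all four numbers remain of a similar order.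

On these data alone, whether the higher number of compound 3 follows from the dimethylamino group itself or from where it sits on the ring stays open, as does how a 4-ethylphenyl, a 2-(dimethylamino)phenyl or a plain phenyl would compare. Nothing shown here gives a reason for any of these numbers.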